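The compounds below may be only part of what the source reports. "The series", "measured", "known", "first", "only" and "open" are said of these compounds alone.

Compounds measured in a functional assay on MIA PaCa-2 cells (Homo sapiens) for antiproliferative activity, read by sulforhodamine B assay, with a stated time of 48 h; on this read-out lower numbers stand for stronger inhibition of growth and higher numbers for weaker inhibition of growth:
compound 1 `COc1ccc(Cn2cc(CNC(=O)c3cn(-c4ccccc4)nc3-c3ccccc3)nn2)cc1` gives 10200 nM
compound 2 `COc1ccc(Cn2cc(CNC(=O)c3cn(-c4ccccc4)nc3-c3ccccc3)nn2)cc1OC` gives 8200 nM
compound 3 `COc1cc(Cn2cc(CNC(=O)c3cn(-c4ccccc4)nc3-c3ccccc3)nn2)cc(OC)c1` gives 190 nM

Among these three, compound 1 holds the highest number, that is the weakest growth inhibition. Its nearest neighbour is compound 2, with a 1.2-fold lower number from compound 1 to compound 2 (0.09 log units; within the scatter), while compound 3 stands far off, with a 54-fold lower number from compound 1 to compound 3 (1.73 log units; beyond the scatter).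

Compound 4 `COc1ccc(Cn2cc(CNC(=O)c3cn(-c4ccccc4)nc3-c3ccc(F)cc3)nn2)cc1` differs from compound 1 by fluoro in place of hydrogen on an aromatic carbon. Going by the values given here, none of the measured steps touches this part of the shared core: the two steps seen so far, a 1.2-fold lower number from compound 1 to compound 2 (0.09 log units; within the scatter) and a 43-fold lower number from compound 2 to compound 3 (1.64 log units; beyond the scatter), alter the methoxy pattern on the benzyl ring, not the phenyl group carrying the new fluoro. Among the compounds with values here, with no step bearing on this change, no shift beyond the scatter is expected, and compound 4 is estimated at 9000 nM (range 3000 nM to 30000 nM), a step of a 1.1-fold lower number from compound 1 to compound 4 (0.05 log units; within the scatter).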

Compound 4, concentration for 50% growth inhibition: 3700 nM
Compound 4: the middle estimate sits 2.4-fold (0.39 log units) above what was measured; low and high end bracket the measured number.
By their numbers in this assay, from the lowest: compound 3; then compound 4; then compounds 2 and 1 (each within the scatter of the next).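

Changing phenyl to 4-fluorophenyl on the shared core brings a 2.8-fold lower number from compound 1 to compound 4 (0.44 log units; beyond the scatter) and so a modest gain in growth inhibition. Going by these compounds alone, this shows that the core itself can respond, whereas the earlier steps changed only the methoxy pattern on the benzyl ring. No measurement shown explains the gain.

Going by these compounds, it remains open whether a chloro or methyl group in the place of the fluoro would match this gain. Also open, on these data alone, is whether the 4-fluorophenyl group would add to the strong inhibition of compound 3 190 nM when the two are combined.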